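This account rests on a few compounds, and the source may have more. Where it says the series, first, only, none or still open, it means among the compounds named here.

Four compounds built on two related cores were run in a functional assay on MDA-MB-231 cells (Homo sapiens) for antiproliferative activity, read by MTT assay, with a stated time of 48 h; a higher number here means a weaker inhibitor, a lower number a stronger inhibitor. Compound 1 `COc1ccc(N(C)c2ccnc(Cl)n2)cc1[N+](=O)[O-]` gives 8120 nM in this assay. Compound 2 `COc1ccc(N(C)c2ccnc(Cl)n2)cc1O` differs from compound 1 in one place: hydroxy in place of nitro on an aromatic carbon. This change brought a 9.7-fold lower number from compound 1 to compound 2 (0.99 log units; beyond the scatter), so compound 2 gives 833 nM in this assay.

Compound 3 `COc1ccc(N(C)c2cc(C)nc(C)n2)cc1[N+](=O)[O-]` shares the substitution pattern of compound 1 but carries a different core; the difference between the two cores is not broken down here. In this assay, going by the values given here, compound 3 gives 3440 nM, which puts it second highest of the three numbers so far, a step beyond the scatter from compound 1 and further still from compound 2.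

Compound 4 `COc1ccc(N(C)c2cc(C)nc(C)n2)cc1O` has not yet been measured. It stands to compound 3 as compound 2 stands to compound 1: hydroxy in place of nitro on an aromatic carbon. The place of the change is the same kind of place, ortho to a methoxy group, though the group meta to it is described only as a large group in compound 4, where in compound 2 it is a group of 9 heavy atoms. This is the same kind of change, not the same change. Because the earlier step gave a 9.7-fold lower number from compound 1 to compound 2 (0.99 log units; beyond the scatter), a comparable step is expected here, with an 8.6-fold lower number from compound 3 to compound 4 (0.93 log units; beyond the scatter) as the estimated move. Compound 4 is therefore expected to give 400 nM in this assay, with the likely range spanning 150 nM to 1200 nM.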

Compound 4, half-maximal inhibitory concentration: 1100 nM
Beside the measured number, compound 4's estimate is 2.8-fold (0.44 log units) below it; measured number inside the range.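

Replacing nitro with hydroxy on the aromatic carbon again lowered the number in this assay, with a 3.1-fold lower number from compound 3 to compound 4 (0.50 log units; beyond the scatter), so the direction of the change carried over from one core to the other in the two pairs shown. Going by these compounds alone, the size of the step did not carry over, and the gain on the core of compound 3 was clearly smaller than on the core of compound 1: the same change on two cores in this assay, a 9.7-fold lower number (0.99 log units; beyond the scatter) from compound 1 to compound 2 and a 3.1-fold lower number (0.50 log units; beyond the scatter) from compound 3 to compound 4, 3.1-fold (0.49 log units) apart, beyond the scatter of two such steps With only two pairs, this shows neither a general rule for the series nor why the step differs, and the difference between the two cores is not broken down, so no single part of either core can be held to set its size.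

The compounds shown leave open whether an amine or a carboxylic acid on the same aromatic carbon would lower the number as hydroxy does, and whether the step would keep its direction on either core with such a group. They also leave open which feature of the cores governs the size of the step, a question that would need a pair of cores differing in one place only.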